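This account rests on a few compounds, and the source may have more. Where it says the series, first, only, none or still open, it means among the compounds named here.

Measured compounds in a functional assay on HEK293 cells for positive allosteric modulation of metabotropic glutamate receptor 5 (Homo sapiens), read by calcium flux; on this read-out higher numbers stand for larger maximal responses and lower numbers for smaller maximal responses:
compound 1, `O=C(c1ccc(F)cc1)N1CCc2nc(COc3ccccn3)oc2C1`, gives 75%
compound 2, `O=C(c1ccc(F)cc1)N1CCc2nc(COc3cccnc3)oc2C1`, gives 40%
compound 3, `O=C(c1ccccc1)N1CCc2nc(COc3cccc(F)c3)oc2C1`, gives 73%

Compound 3 stands second highest of the three numbers in this assay. Its nearest neighbour is compound 1, whose value lies within the scatter of that of compound 3, so the two cannot be put in order; compound 2 lies beyond the scatter below it. For the measured compounds named here, the one step measured at a single place, a number 35 percentage points lower from compound 1 to compound 2 (beyond the scatter), concerns the group on the oxygen on the saturated carbon, not the group on the carbonyl carbon.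

Compound 4, `O=C(c1cc(F)cc(F)c1)N1CCc2nc(COc3cccc(F)c3)oc2C1`, differs from compound 3 at the carbonyl carbon: 3,5-difluorophenyl in place of phenyl on a carbonyl carbon. Going by the values given here, no measured pair differs at that carbon alone; compounds 1 and 3 differ there and also on the oxygen, and their values lie within the scatter of each other. Among the compounds with values here, with no measured step bearing directly on this change, the expected step in this assay is none beyond the scatter, no change at the digits printed from compound 3 to compound 4 (within the scatter). Compound 4 is therefore estimated at 73%, with a range from 55% to 90%.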

Compound 4, largest response reached (reported as percent of maximum), in percent of the reference or control that the assay uses: 42%
Compound 4: the middle estimate sits 31 percentage points above what was measured; the measured number lies below the stated range.
By their numbers in this assay, from the lowest: compounds 2 and 4 (each within the scatter of the next); then compounds 3 and 1 (each within the scatter of the next).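

In this assay, the group on the carbonyl carbon proves able to change the maximal response: with the group on the oxygen held constant, the result is a number 31 percentage points lower from compound 3 to compound 4 (beyond the scatter). Until now, no measured pair had differed at that carbon alone, so only the group on the oxygen had been shown to move the read-out beyond the scatter, and the group on the carbonyl carbon now joins it. Nothing measured here accounts for the lower number carried by the 3,5-difluorophenyl group.

From the compounds shown here alone, it remains open whether a single fluorine on the phenyl would produce a similar step, and whether the step would carry over to compounds bearing pyridin-2-yl on the oxygen. Also open, going by these compounds, is how a chlorine on the phenyl, or a cyclohexyl group or an amine such as piperidine on the carbonyl carbon, would read in this assay.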